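Replacing the isopropyl end of compound 2 with a piperidinyl chain

The compounds below may be only part of what the source reports. "The series", "measured", "known", "first", "only" and "open" are said of these compounds alone.

Of the compounds shown here, three sharing one core have been tested in a functional assay on PC-3 cells (Homo sapiens) for antiproliferative activity, read by MTT assay, with a stated time of 72 h; on this read-out higher numbers stand for weaker inhibition and lower numbers for stronger inhibition. Compound 1 `COc1cc2ncnc(N3CCc4ccccc43)c2cc1NC(=O)/C=C/C(C)C` gives 6530 nM in this assay. Compound 2 `CC(C)/C=C/C(=O)Nc1cc2c(N3CCc4ccccc43)ncnc2cc1O[C@@H]1CCOC1` gives 11200 nM in this assay. Compound 3 `CC(C)/C=C/C(=O)Nc1cc2c(N3CCCc4ccccc43)ncnc2cc1O[C@@H]1CCOC1` gives 8510 nM in this assay. Compound 2 holds the highest of the three numbers, but the two measured steps leading to and from it, a 1.7-fold higher number from compound 1 to compound 2 (0.23 log units; within the scatter) and a 1.3-fold lower number from compound 2 to compound 3 (0.12 log units; within the scatter), both stay within the scatter, so none of the three compounds can be called weaker or stronger than another.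

Compound 4 `O=C(/C=C/CN1CCC(CO)CC1)Nc1cc2c(N3CCc4ccccc43)ncnc2cc1O[C@@H]1CCOC1` differs from compound 2 in one place: (4-(hydroxymethyl)piperidin-1-yl)methyl in place of isopropyl on a double-bonded chain carbon bound to a double-bonded chain carbon. Neither measured step touches this part of the molecule; one changes the group on the ring oxygen, the other the ring-fused amine. Among the measured compounds shown here, nothing measured therefore tells how the chain end behaves, and the only guide is that both changes made elsewhere left the number within the scatter.

On that basis the expectation for compound 4 is a value close to that of compound 2, with a 2.2-fold lower number from compound 2 to compound 4 (0.35 log units; beyond the scatter) as the estimated step and a wide range. Compound 4 is estimated at 5000 nM, between 1200 nM and 20000 nM.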

Compound 4, half-maximal inhibitory concentration: 3310 nM
Compound 4: the middle estimate sits 1.5-fold (0.18 log units) above what was measured; measured number inside the range.
By their numbers in this assay, from the lowest: compounds 4, 1, 3 and 2 (each within the scatter of the next, the first and the last beyond it).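

In this assay, among the compounds shown here, the chain end is the first place in this set where a single change moves the number beyond the scatter: putting (4-(hydroxymethyl)piperidin-1-yl)methyl in place of isopropyl gives a 3.4-fold lower number from compound 2 to compound 4 (0.53 log units; beyond the scatter), a modest step towards stronger inhibition. This position, on a double-bonded chain carbon bound to a double-bonded chain carbon, therefore accepts a group of 9 heavy atoms in place of one of 3 without any loss of antiproliferative activity, whereas the changes on the ring oxygen and at the ring-fused amine stayed within the scatter. The swap adds a nitrogen, a six-membered ring and a hydroxyl together, and nothing available explains the lower number or ties it to any one of these parts.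

The compounds shown leave open whether the piperidine ring or its hydroxymethyl group goes with the lower number, which a plain piperidin-1-yl or a morpholin-4-yl end would help to separate. They also leave open whether the same chain end would give a similar step on compound 1 or compound 3.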